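Carboxy for hydroxy on the amide aryl of the shared core

The source may report more compounds than this note shows. Statements on the series, on what has been measured and on what is new or still open speak of the compounds shown alone.

Compound 1 `CC(C)=CCCC1=CC[C@@H](C(=O)Nc2ccc(C(=O)O)cc2)[C@H](c2ccccc2)C1` is a cyclohexene acid amide of the shared core; in an assay on isolated protein for inhibition of Apoptosis regulator Bcl-2 (Homo sapiens), read by fluorescence polarization, with stated times of 5 min and 10 min (a higher number here means a weaker inhibitor, a lower number a stronger inhibitor), compound 1 gives 2200 nM. Compound 2 `CC(C)=CCCC1=CC[C@H](C(=O)Nc2ccc(O)cc2)[C@@H](c2ccccc2)C1` carries hydroxy in place of that carboxy. In this assay compound 2 gives only a limit, > 23000 nM, and so sits at the limit of > 23000 nM in this assay, at which 1 of the 2 values shown sits. Compound 3 `CC(C)=CCCC1=CC[C@H](C(=O)Nc2ccc(C(=O)O)cc2)[C@@H](c2ccccc2)C1` has not been measured; it differs from compound 2 by carboxy in place of hydroxy on an aromatic carbon. A step toward stronger inhibition beyond the scatter is expected, since the same carboxy is present in compound 1 at 2200 nM. For compound 3 the estimate is 8000 nM, within 2000 nM to 30000 nM, a step of an at least 2.8-fold lower number from compound 2 to compound 3 (0.45 log units; beyond the scatter).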

Compound 3, inhibition constant: > 23000 nM
Compound 3: a limit, no number (the forecaster's own chance of this, stated with the estimate: 35%); middle value at least 2.8-fold (0.45 log units) from the limit.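

In this assay compound 3 gives > 23000 nM, which is a limit; compound 2 also stands at a limit, so the step from hydroxy to carboxy in this configuration cannot be read. The carboxy alone does not secure measurable inhibition: the pair shows an at least 10-fold higher number from compound 1 to compound 3 (1.01 log units; beyond the scatter), and this step rests on configuration alone: the fact that compounds 1 and 3 differ only in the configuration as drawn

From the compounds shown here alone, it remains open how hydroxy behaves in the configuration of compound 1. Also open, going by these compounds, is whether an amine on that aromatic carbon would keep the inhibition seen with compound 1.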